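The compounds below may be only part of what the source reports. "The series", "measured", "known", "first", "only" and "open" are said of these compounds alone.

Values in a functional assay on cells (Homo sapiens) for cytotoxicity, read by MTT assay, with a stated time of 48 h; a lower number here means a stronger inhibitor, a higher number a weaker inhibitor:
Compound 1 `CN(C)CCCCCN(C)C1=Nc2ccccc2C(CC(=O)NCc2ccccc2)N1c1ccc(-c2ccccn2)cc1`: > 5000 nM
Compound 2 `CN(C)CCCCN(C)C1=Nc2ccccc2C(CC(=O)NCc2ccccc2)N1c1ccc(-c2ccccc2)cc1`: 3970 nM
Compound 3 `CN(C)CCN1CCN(C2=Nc3ccccc3C(CC(=O)NCc3ccccc3)N2c2ccc(-c3ccccc3)cc2)CC1`: 2390 nM

The entry for compound 1 is a limit and not a number. That leaves two numeric values in the series, and they lie within the scatter of each other: a 1.7-fold lower number from compound 2 to compound 3 (0.22 log units; within the scatter). Compound 3 therefore stands level with compound 2 on the numbers available.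

The next compound is compound 4 `CN(C)CCN1CCN(C2=Nc3ccccc3C(CC(=O)NCc3ccccn3)N2c2ccc(-c3ccccc3)cc2)CC1`. The change is pyridin-2-yl in place of phenyl on a saturated chain carbon bound to an amide-type nitrogen, which turns benzylcarbamoyl into ((pyridin-2-yl)methyl)carbamoyl.

Among the compounds with values here, no measured step covers this change, since compound 1, compound 2 and compound 3 all carry benzylcarbamoyl. Within the data shown here, the one measured step, a 1.7-fold lower number from compound 2 to compound 3 (0.22 log units; within the scatter), concerns the amine group on a carbon with a double bond to nitrogen, so it gives no direct size for this replacement. It does show a change of that kind staying within the scatter in this assay. With no direction supported by the data, the expected result is a 1.2-fold higher number from compound 3 to compound 4 (0.07 log units; within the scatter), with no shift beyond the scatter anticipated. For compound 4 the estimated value is 2800 nM, with an expected range of 1200 nM to 5000 nM.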

Compound 4, half-maximal inhibitory concentration: > 5000 nM
Compound 4: no number, only a limit; the forecaster's own chance of this, stated with the estimate: 20%; middle value at least 1.7-fold (0.25 log units) away from the limit.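

In this assay the place on a saturated chain carbon bound to an amide-type nitrogen responds to the ring it carries: pyridin-2-yl in place of phenyl gives an at least 2.0-fold higher number from compound 3 to compound 4 (0.32 log units; beyond the scatter). Compounds 1, 2 and 3 all carry benzylcarbamoyl, and the one step among them, at the amine group on a carbon with a double bond to nitrogen, stays within the scatter, so this is the first step shown that goes beyond it. Compound 4 gives a limit and not a number, so the step has only a lower bound and its full size cannot be read: the limit of > 5000 nM in this assay, at which 2 of the 4 values shown sit.

The compounds shown leave open whether the weakening follows from a ring nitrogen at any position or from the pyridin-2-yl arrangement alone, a question that pyridin-3-yl and pyridin-4-yl at this place would address. They also leave open whether a longer chain, such as 2-phenylethyl on the amide nitrogen, would be tolerated, and whether the same replacement weakens compounds with the (4-(dimethylamino)butyl)(methyl)amino group of compound 2.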